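The source may hold more compounds than are shown below. What is called first, only, known or untested is meant among the compounds shown, and "the series" means these compounds.

Three compounds built on one shared core were tested in an ADME assay on MDBK cells (Bos taurus) for cytotoxicity, read by MTT assay; on this read-out higher numbers stand for lower toxicity in this test and lower numbers for higher toxicity in this test. Compound 1 `COc1ccc(OCCCCCCN2C[C@H](O)[C@@H](O)[C@H](O)[C@H]2CO)cc1` gives a reading of > 500000 nM in this assay, which is a limit of the assay rather than a number. Compound 2 `CC1CCCC(OCCCCCCN2C[C@H](O)[C@@H](O)[C@H](O)[C@H]2CO)C1C` likewise reaches only a limit, > 500000 nM, in this assay. Compound 3 `CC1CCC(OCCCCCCN2C[C@H](O)[C@@H](O)[C@H](O)[C@H]2CO)CC1C` also stands at a limit, > 500000 nM, in this assay. All three values shown are therefore limits, and compound 3 can be placed no more precisely than that. Compound 4 `CCC1CCC(OCCCCCCN2C[C@H](O)[C@@H](O)[C@H](O)[C@H]2CO)CC1` is not yet measured; it differs from compound 3 by a group of 8 heavy atoms (8 carbon; one six-membered non-aromatic ring of carbon only) in place of a group of 8 heavy atoms (8 carbon; one six-membered non-aromatic ring of carbon only), on an oxygen on a saturated carbon. The measured steps that bear on this change are a step that the two limits leave unreadable from compound 1 to compound 2, a step that the two limits leave unreadable from compound 1 to compound 3 and a step that the two limits leave unreadable from compound 2 to compound 3, none of which can be sized, since (the limit of > 500000 nM in this assay, at which 3 of the 3 values shown sit). No step beyond the scatter is expected in this assay in either direction, and compound 4 is expected to sit at the limit again, an estimated step that the limit leaves unreadable from compound 3 to compound 4. The estimate for compound 4 is 700000 nM, with an expected range from 250000 nM to 3000000 nM.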

Compound 4, half-maximal cytotoxic concentration: > 500000 nM
Compound 4 gave a limit, no number; the forecaster's own chance of this, stated with the estimate: 85%; the middle value does not contradict the limit.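

No step can be read between compound 4 and compound 1, compound 2 or compound 3, because each reading is a limit and not a number: the limit of > 500000 nM in this assay, at which 4 of the 4 values shown sit.
On these data alone, what stays open is whether these four compounds differ at all in this assay.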